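This account rests on a few compounds, and the source may have more. Where it says the series, first, only, none or still open, it means among the compounds named here.

The three compounds measured so far in a functional assay on PC-12 cells (Rattus norvegicus) for cytotoxicity, read by MTT assay, with stated times of 3 h and 2 h, tested at 50 uM; a higher number here means a stronger effect of the compound at the concentration tested, a lower number a weaker effect:

Compound 1, `CC(=O)c1cc2ccc(OCCCCCn3cc(CNC(=O)CCCCC4CCSS4)nn3)cc2oc1=O`, gives 18.2%.
Compound 2, `COc1ccc(-c2cc3ccc(OCCCCCn4cc(CNC(=O)CCCCC5CCSS5)nn4)cc3oc2=O)cc1OC`, gives 55%.
Compound 3, `O=C(CCCCC1CCSS1)NCc1cn(CCCCCOc2ccc3cc(-c4ccc(Br)cc4)c(=O)oc3c2)nn1`, gives 53.6%.

Compound 3 stands second highest of these three numbers. Its nearest neighbour is compound 2, and the difference between them, a number 1.4 percentage points lower from compound 2 to compound 3 (within the scatter), is within the scatter of repeated measurements. Its furthest neighbour is compound 1, and the step of a number 35.4 percentage points higher from compound 1 to compound 3 (beyond the scatter) is large and beyond the scatter.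

Compound 4 is `O=C(CCCCC1CCSS1)NCc1cn(CCCCCOc2ccc3cc(-c4ccc(Cl)c(Cl)c4)c(=O)oc3c2)nn1`. Compared with compound 3 the change is 3,4-dichlorophenyl in place of 4-bromophenyl on an aromatic carbon.

For the measured compounds named here, two measured steps bear on this. The steps of a number 36.8 percentage points higher from compound 1 to compound 2 (beyond the scatter) and a number 35.4 percentage points higher from compound 1 to compound 3 (beyond the scatter) show that putting either aryl group in place of the acetyl raises the number strongly, while the step of a number 1.4 percentage points lower from compound 2 to compound 3 (within the scatter) shows that the two aryl groups themselves give numbers that cannot be told apart. Compound 4 keeps an aryl group at the same place, so no step beyond the scatter is expected in this assay, only a change of about a number 0.6 percentage points lower from compound 3 to compound 4 (within the scatter).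

Compound 4 is therefore estimated to give 53% in this assay, within a range from 40% to 66%.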

Compound 4, a percentage reported as activity, at one concentration (the size of the read-out at that concentration, not a potency): 66.2%
Beside the measured number, compound 4's estimate is 13.2 percentage points below it; the measured number lies above the stated range.
By their numbers in this assay, from the lowest: compound 1; then compounds 3 and 2 (each within the scatter of the next); then compound 4.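

In this assay, the aryl groups at this aromatic carbon no longer look interchangeable: 3,4-dichlorophenyl gives a number 12.6 percentage points higher from compound 3 to compound 4 (beyond the scatter) and a number 11.2 percentage points higher from compound 2 to compound 4 (beyond the scatter), even though 4-bromophenyl and 3,4-dimethoxyphenyl could not be told apart. Compound 4 has the highest number of the series, and replacing acetyl with this aryl group gives a number 48 percentage points higher from compound 1 to compound 4 (beyond the scatter), so the groups on the aryl ring matter here as well as the presence of the ring itself. The data at hand offer no explanation for the higher number with 3,4-dichlorophenyl.

The compounds shown do not separate the contribution of each chlorine, so it remains open whether 3-chlorophenyl, 4-chlorophenyl or plain phenyl would match 3,4-dichlorophenyl or fall nearer 4-bromophenyl. On these data alone, it also remains open whether the same ranking would hold at other concentrations in this assay, or whether a pyridine ring at this carbon, or a longer chain linking the shared core to the rest of the molecule, would change the number.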